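From Acetyl to tert-Butoxycarbonyl: An Expected Step

A few compounds are considered here, and "the series" means these few. Any claim that something is new, unique, unknown or untested is made for them only; others in the source may bear on it.

Of the compounds shown here, two have been measured so far. Compound 1 `CCCCCCCCCCCCSC[C@H](NC(C)=O)C(=O)C=[N+]=[N-]` is the weaker of the pair: in a functional assay on MOLT-3 cells (Homo sapiens) (on this read-out lower numbers stand for stronger inhibition and higher numbers for weaker inhibition), compound 1 gives 22900 nM. Compound 2 `CCCCCCCCCCCCSC[C@H](NC(C)=O)C(=O)CCl` differs from it only at the ketone end, and in this assay compound 2 gives 2300 nM. Among the compounds with values here, the single measured step, a 10-fold lower number from compound 1 to compound 2 (1.00 log units; beyond the scatter), leaves compound 2 with the lowest number of the two, clearly separated from compound 1.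

Compound 3 `CCCCCCCCCCCCSC[C@H](NC(=O)OC(C)(C)C)C(=O)CCl` has not yet been measured. It keeps everything of compound 2 except one group on the amide side: tert-butoxy in place of methyl on a carbonyl carbon. Within the data shown here, no measured step touches that part of the molecule; the only step on record, a 10-fold lower number from compound 1 to compound 2 (1.00 log units; beyond the scatter), concerns the other end of the chain and so says nothing direct about this change. With no comparison to lean on, the expected step is no change at the digits printed from compound 2 to compound 3 (within the scatter), a change not beyond the scatter. Compound 3 is therefore estimated at 2300 nM in this assay, with a range from 700 nM to 7500 nM.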

Compound 3, half-maximal inhibitory concentration: 15500 nM
Compound 3: the middle estimate sits 6.7-fold (0.83 log units) below what was measured, and the stated range ends below it.
By their numbers in this assay, from the lowest: compound 2; then compounds 3 and 1 (each within the scatter of the next).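

Within the data shown here, this is the first measured change on the amide side of the molecule, and it shows that this position matters: in this assay, putting tert-butoxy in place of methyl on this carbonyl carbon gives a 6.7-fold higher number from compound 2 to compound 3 (0.83 log units; beyond the scatter). Since higher numbers mean weaker inhibition here, the acetyl group of compound 2 does better than the tert-butoxycarbonyl group of compound 3, so the ketone end is not the only part of these molecules that can move the number. No measurement at hand says why this swap weakens inhibition.

With only these two groups compared at this position, a single step cannot show whether the loss tracks the number of atoms in the new group, the oxygen it brings in, or something else, and a tert-butyl group, with its carbons but no such oxygen, or an ethyl group would help to separate these readings. As far as these compounds go, it also stays open whether the same swap would have a similar effect on a molecule carrying the ketone end of compound 1.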